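Pyrrolyl to phenyl on the acrylonitrile chain: compound 4

This account rests on a few compounds, and the source may have more. Where it says the series, first, only, none or still open, it means among the compounds named here.

Measured so far:
compound 1 `N#C/C(=C\c1c[nH]c2ccccc12)C(=O)c1c[nH]c2ccccc12` — a functional assay on NCI-H460 cells (Homo sapiens) for inhibition, read by MTT assay, with a stated time of 72 h; a lower number here means a stronger inhibitor of growth, a higher number a weaker inhibitor of growth: 7600 nM
compound 2 `N#C/C(=C\c1ccc[nH]1)C(=O)NCc1ccc(Cl)c(Cl)c1` — this assay: > 50000 nM
compound 3 `COc1ccc(CNC(=O)/C(C#N)=C/c2ccc(C)o2)cc1` — this assay: > 100000 nM

Compound 2 gives only a limit in this assay, > 50000 nM, not a number. Compound 3 also gives only a limit, > 100000 nM. For the measured compounds named here, compound 1 is the one compound of the three with a measured concentration, 7600 nM; it shares the acrylonitrile chain but carries neither the benzylamide nor a five-membered ring. Going by these compounds, of the values shown, one sits at the limit of > 50000 nM in this assay, at which 1 of the 3 values shown sits, and one at the limit of > 100000 nM in this assay, at which 1 of the 3 values shown sits, so compound 2 stands with the weakest end of the set, though its true value is unknown.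

Compound 4 `N#C/C(=C\c1ccccc1)C(=O)NCc1ccc(Cl)c(Cl)c1` differs from compound 2 in one place: phenyl in place of 1H-pyrrol-2-yl on a double-bonded chain carbon bound to a double-bonded chain carbon. Going by the values given here, no measured pair in the set carries this exchange, so the size of the step is open. With compound 2 at a limit, the step from compound 2 to compound 4 in this assay is expected to be small or not beyond the scatter, in either direction, an at least 1.1-fold lower number from compound 2 to compound 4 (0.04 log units; that floor lies within the scatter). Compound 4 is expected at 45000 nM, with a range from 12000 nM to 150000 nM, and a fair chance that this assay again returns only a limit.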

Compound 4, concentration for 50% growth inhibition: 61000 nM
Compound 4: middle estimate off by 1.4-fold (0.13 log units), on the low side, within the range that was stated.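

For the compounds shown here, compound 2 gives only a limit in this assay, > 50000 nM, so no step from compound 2 to compound 4 can be read. The compounds shown leave open the size and direction of the change from 1H-pyrrol-2-yl to phenyl, with no pair carrying this exchange at two measured numbers.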